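Bromo in place of nitro: expectation for compound 3

The compounds below may be only part of what the source reports. "The series", "measured", "known", "first", "only" and "open" are said of these compounds alone.

Of the compounds shown here, two have numbers so far in a functional assay on the whole organism with Mus musculus as the target; on this read-out lower numbers stand for an effect already at smaller amounts and higher numbers for an effect only at larger amounts of compound. Compound 1 `COc1cc2c(cc1OC)C(c1cccc(N)c1)=NN=C(S)C2` gives 9.1 umol/kg. Compound 2 `COc1cc2c(cc1OC)C(c1ccc([N+](=O)[O-])cc1)=NN=C(S)C2` gives 69.8 umol/kg, the higher of the two numbers, and its gap to compound 1 lies beyond the usual scatter. Compound 3 `COc1cc2c(cc1OC)C(c1ccc(Br)cc1)=NN=C(S)C2` is still unmeasured. It keeps the shared core and differs from compound 2 as follows: bromo in place of nitro on an aromatic carbon. This puts bromo in place of nitro on an aromatic carbon, para to a large group. Among the compounds with values here, no measured pair isolates a single change, so the expectation rests on two anchors only: compound 2 at 69.8 umol/kg and compound 1 at 9.1 umol/kg. The expected move is a 2.3-fold lower number from compound 2 to compound 3 (0.37 log units; beyond the scatter), a modest step towards a lower number, near the edge of the scatter. For compound 3 the estimate is 30 umol/kg, with an expected range of 10 umol/kg to 90 umol/kg.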

Compound 3, dose for half-maximal effect: 33.3 umol/kg
Estimate against measurement, compound 3: 1.1-fold (0.05 log units) below; measured number inside the range.
By their numbers in this assay, from the lowest: compound 1; then compound 3; then compound 2.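

In this assay, within the data shown here, the exchange of nitro for bromo on an aromatic carbon, para to a large group, gives the first step that changes only this substituent: a 2.1-fold lower number from compound 2 to compound 3 (0.32 log units; beyond the scatter), a modest move with one heavy atom and no hydrogen-bond acceptor in place of three heavy atoms and two acceptors. Exchanging the whole aryl group gives a 3.7-fold higher number from compound 1 to compound 3 (0.56 log units; beyond the scatter), so 4-bromophenyl does not reach the number of 3-aminophenyl, although this step changes both the substituent and its place on the ring. No measured property accompanies these compounds, so neither step can be tied to a cause.

Still open, from the compounds shown here alone, is whether the lower number of compound 1 belongs to the amino group or to where it sits on the ring, which an amine in the place of bromo would separate. Also open, going by these compounds, is how a carboxylic acid or a fluoro group in that place would compare with nitro and bromo.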